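Changing the aryl ketone group of compound 1

The compounds below may be only part of what the source reports. "The series", "measured", "known", "first", "only" and "open" are said of these compounds alone.

compound 1, `COc1cc(-c2cc(/C=C/C(=O)c3ccc(Cl)c(Cl)c3)[nH]n2)cc(OC)c1OC`: -53%
compound 2, `COc1ccc(-c2cc(/C=C/C(=O)c3ccc(N)cc3)[nH]n2)cc1OC`: -98%

In a functional assay on BT-549 cells (Homo sapiens) for cytotoxicity, read by sulforhodamine B assay, with a stated time of 48 h, tested at 100 uM (a higher number here means a weaker effect of the compound at the concentration tested, a lower number a stronger effect), compound 1 gives -53%, the highest of the two numbers. Compound 2 gives -98%, a number lower by a margin beyond the usual scatter; as the two structures differ in more than one place, only the two values themselves can be compared. Compound 3, `COc1ccc(C(=O)/C=C/c2cc(-c3cc(OC)c(OC)c(OC)c3)n[nH]2)cc1OC`, has not been measured. It differs from compound 1 in one place: 3,4-dimethoxyphenyl in place of 3,4-dichlorophenyl on a carbonyl carbon. Going by the values given here, no pair of measured compounds differing in a single spot is available, so the size of this step cannot be read off directly. In this assay the step is expected to be a number 27 percentage points lower from compound 1 to compound 3 (beyond the scatter), toward a stronger effect. Compound 3 is estimated at -80%, with a range from -105% to -45%.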

Compound 3, a percentage reported as activity, at one concentration (the size of the read-out at that concentration, not a potency): -75%
Beside the measured number, compound 3's estimate is 5 percentage points below it; the range from low to high includes it.
By their numbers in this assay, from the lowest: compound 2; then compound 3; then compound 1.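

In this assay, putting 3,4-dimethoxyphenyl in place of 3,4-dichlorophenyl on a carbonyl carbon gives a number 22 percentage points lower from compound 1 to compound 3 (beyond the scatter). Going by these compounds alone, this is the first change here made in one place only, and it shows that the read-out responds to the aryl group at this position while the rest of compound 1 stays fixed. No measurement available here accounts for the step.

Going by these compounds, whether a trifluoromethyl or a carboxylic acid on this ring would move the number further, and in which direction, remains open. So does whether the same swap gives a similar step on another core.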